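Notes on compounds 1 to 4, with one estimate

The compounds below may be only part of what the source reports. "The series", "measured", "known", "first", "only" and "open" are said of these compounds alone.

Measured so far:
Compound 1 `COc1ccc2[nH]c(C(=O)N3CC(=O)N(Cc4ccccc4)[C@@H](COCc4ccccc4)C3)cc2c1` in an ADME assay on Vero cells (Chlorocebus sabaeus) for cytotoxicity, with a stated time of 7 days (on this read-out lower numbers stand for higher toxicity in this test and higher numbers for lower toxicity in this test), gives a limit, > 30000 nM.
Compound 2 `COc1cccc(CN2C(=O)CN(C(=O)c3cc4cc(OC)ccc4[nH]3)C[C@@H]2c2ccccc2)c1` in this assay gives a limit, > 10000 nM.
Compound 3 `COc1ccc2[nH]c(C(=O)N3CC(=O)N(Cc4ccccc4)[C@@H](N4CCC(Cc5ccccc5)CC4)C3)cc2c1` in this assay gives a limit, > 30000 nM.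

None of the three values in this assay is a number; each is a limit of the assay. Compound 1 stands at the limit of > 30000 nM in this assay, at which 2 of the 3 values shown sit, shared with compound 3, while compound 2 sits at the limit of > 10000 nM in this assay, at which 1 of the 3 values shown sits. Among the compounds with values here, no step between measured compounds can be computed, and no ordering among the three can be read from limits alone.

Compound 4 `COc1ccc2[nH]c(C(=O)N3CC(=O)N(Cc4ccccc4)[C@@H](CN4CC5CC5C4)C3)cc2c1` is not yet measured in this assay. It differs from compound 1 by a group of 6 heavy atoms (5 carbon, 1 nitrogen; one three-membered non-aromatic ring of carbon only, one five-membered non-aromatic ring with 1 hetero atom) in place of a group of 8 heavy atoms (7 carbon, 1 oxygen; one six-membered aromatic ring of carbon only), on a saturated chain carbon bound to a saturated ring carbon. The three measured compounds carry quite different groups on the shared core and all reach only a limit in this assay, which gives no ground to expect compound 4 to move away from that picture.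

The step from compound 1 to compound 4 in this assay is expected to be none beyond the scatter, that is a step that the limit leaves unreadable from compound 1 to compound 4. For compound 4 the estimate in this assay is 40000 nM, expected between 15000 nM and 120000 nM, and most likely reported again as a limit rather than a number.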

Compound 4, half-maximal cytotoxic concentration: 13800 nM
Compound 4: middle estimate off by 2.9-fold (0.46 log units), on the high side, and the stated range ends above it.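

The benzyloxy group on the saturated chain carbon bound to a saturated ring carbon can be replaced with a measurable result in this assay: the group of 6 heavy atoms, with its three-membered ring of carbon only and its five-membered ring with 1 hetero atom, gives an at least 2.1-fold lower number from compound 1 to compound 4 (0.33 log units; beyond the scatter). This change therefore yields the only number among the compounds shown, so this place is not silent in the assay, as the limits alone might have suggested. The step remains a bound and not a size because compound 1 stands at a limit of the assay: the limit of > 30000 nM in this assay, at which 2 of the 4 values shown sit.

The exchange alters the ring types, the atom count and the hetero atom at once, so the compounds shown do not separate the loss of the benzyloxy group from the entry of the ring nitrogen. Going by these compounds, whether a plain dimethylamino group or a morpholine on the same chain carbon, or a carboxylic acid there, would also give a number in this assay stays open.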